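From 3-methoxyphenyl to 2-methoxyphenyl under an assay limit

This account rests on a few compounds, and the source may have more. Where it says the series, first, only, none or still open, it means among the compounds named here.

Compound 1 `COC1=C(C)C(=O)/C(=C(O)/C=C/c2ccc(Br)cc2)C(=O)C1(C)C`, compound 2 `COC1=C(C)C(=O)/C(=C(O)/C=C/c2ccc(OC)cc2)C(=O)C1(C)C` and compound 3 `COC1=C(C)C(=O)/C(=C(O)/C=C/c2cccc(OC)c2)C(=O)C1(C)C` share one core and differ only in their aromatic group. In a functional assay on HUVEC cells (Homo sapiens) (a lower number here means that less compound is needed, a higher number that more compound is needed for the effect), compound 1 gives < 4 ug/mL, which is a limit and not a number. Compound 2 gives < 4 ug/mL, also a limit. Compound 3 gives < 4 ug/mL, again a limit. Going by the values given here, the whole series so far therefore stands at the limit of < 4 ug/mL in this assay, at which 3 of the 3 values shown sit.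

Compound 4 `COC1=C(C)C(=O)/C(=C(O)/C=C/c2ccccc2OC)C(=O)C1(C)C` has the same atoms joined differently: 2-methoxyphenyl in place of 3-methoxyphenyl on a double-bonded chain carbon bound to a double-bonded chain carbon. A 2-methoxyphenyl takes the place of the 3-methoxyphenyl on a double-bonded chain carbon bound to a double-bonded chain carbon.

The closest comparison is a step that the two limits leave unreadable from compound 2 to compound 3. The others are a step that the two limits leave unreadable from compound 1 to compound 3 and a step that the two limits leave unreadable from compound 1 to compound 2, and neither gives a size either. With no readable step to build on, no change beyond the usual scatter is expected in this assay, in either direction. The expected result is a step that the limit leaves unreadable from compound 3 to compound 4. The estimate for compound 4 is 2 ug/mL, with an expected range from 0.6 ug/mL to 5 ug/mL.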

Compound 4, concentration for half-maximal effect: < 4 ug/mL
Compound 4 gave a limit, no number; the forecaster's own chance of this, stated with the estimate: 75%; the middle value does not contradict the limit.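

Compound 4 gives only a limit in this assay, as do compound 1, compound 2 and compound 3, so no step among them can be read: the limit of < 4 ug/mL in this assay, at which 4 of the 4 values shown sit.

The compounds shown leave open whether 2-methoxyphenyl, 3-methoxyphenyl, 4-methoxyphenyl and 4-bromophenyl differ in this effect at all.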